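The source may hold more compounds than are shown below. What is called first, only, known or untested is meant among the compounds shown, and "the series" means these compounds.

Compound 1 `O=[N+]([O-])c1cccc(Nc2nc(SCc3ccc(C(F)(F)F)cc3)nc3ccccc23)c1` — in a functional assay on MCF7 cells (Homo sapiens) for cytotoxicity, read by MTT assay, with a stated time of 72 h (on this read-out higher numbers stand for weaker inhibition and lower numbers for stronger inhibition), compound 1 gives > 50000 nM, which is a limit of the assay rather than a number.
Compound 2 `COc1cc(Nc2nc(SCc3ccc(C(F)(F)F)cc3)nc3ccccc23)cc(OC)c1` — in this assay compound 2 gives 6990 nM.

Among the measured compounds shown here, compound 2 therefore holds the only numerical value in this set; the other entry is a limit (the limit of > 50000 nM in this assay, at which 1 of the 2 values shown sits). For the measured compounds named here, the one measured step runs an at least 7.1-fold lower number from compound 1 to compound 2 (0.85 log units; beyond the scatter), and it exchanges a 3-nitrophenyl for a 3,5-dimethoxyphenyl on the nitrogen attached to the shared core.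

Compound 3 `COc1ccc(Nc2nc(SCc3ccc(C(F)(F)F)cc3)nc3ccccc23)cc1OC` has not been measured. It differs from compound 2 only in 3,4-dimethoxyphenyl in place of 3,5-dimethoxyphenyl on a nitrogen on an aromatic ring, so the two have the same atoms joined differently. Going by the values given here, no measured step exchanges one dimethoxyphenyl arrangement for another; the step from compound 1 to compound 2 concerns a nitro group against two methoxy groups and does not bear directly on a shift of one methoxy group within the ring. The expected step is therefore none beyond the scatter, with the direction left open.

On that basis compound 3 is estimated at 7000 nM (range 2500 nM to 20000 nM), meaning an expected step of a 1.0-fold higher number from compound 2 to compound 3 (0.00 log units; within the scatter).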

Compound 3, half-maximal inhibitory concentration: > 50000 nM
Compound 3: only a limit was reported; the forecaster's own chance of this, stated with the estimate: 15%; middle value at least 7.1-fold (0.85 log units) away from the limit.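

The earlier step compared a nitro group with two methoxy groups, whereas this one keeps the same atoms and changes only their arrangement on the phenyl ring attached to the nitrogen. In this assay, that rearrangement alone produces a clear difference (an at least 7.1-fold higher number from compound 2 to compound 3 (0.85 log units; beyond the scatter)), so having two methoxy groups on this ring does not by itself give a measurable value among these compounds. Among the compounds shown here, the value of compound 3, > 50000 nM, is a limit of the assay and not a number, and the step between the two limits cannot be read, leaving compound 2 with the only numerical value and the other two compounds at the same limit: the limit of > 50000 nM in this assay, at which 2 of the 3 values shown sit.

The compounds shown leave open whether a single methoxy group, an ethoxy group or a hydroxyl group on this ring would give a numerical value. They also do not tell whether the difference between the two dimethoxyphenyl arrangements would persist if the trifluoromethyl group elsewhere in the molecule were replaced by a nitrile or a chlorine atom.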